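Replacing the Anilide of Compound 1 with a Pyridinylamine

The compounds below may be only part of what the source reports. "The series", "measured", "known", "first", "only" and "open" are said of these compounds alone.

Compound 1 `O=C(Nc1ccccc1)c1cnc(NCc2c(F)ccc3c2CCO3)n2cnnc12`: 14 mL.min-1.g-1
Compound 2 `Cc1ncccc1-c1cnc(NCc2c(F)ccc3c2CCO3)c2ncc(=O)[nH]c12`: 21 mL.min-1.g-1
Compound 3 `Cc1cc(-c2cnc(NCc3c(F)ccc4c3CCO4)c3cn[nH]c(=O)c23)n(C)n1`: 24 mL.min-1.g-1

Three compounds sharing the same fluorinated dihydrobenzofuranylmethylamine side chain have been run in an ADME assay on microsomes from liver (Homo sapiens) for metabolic stability, read by LC-MS, using NADPH, with stated times of 5 min and 30 min, tested at 1 uM; on this read-out lower numbers stand for slow clearance and higher numbers for fast clearance. Compound 1 returns 14 mL.min-1.g-1, compound 2 returns 21 mL.min-1.g-1 and compound 3 returns 24 mL.min-1.g-1. Compound 1 sits at the low end of these three numbers, but its separation from compound 2 and from compound 3 is within the usual scatter of this assay, so the three compounds cannot be told apart on this read-out.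

Compound 4 `CN(c1cccnc1)c1cnc(NCc2c(F)ccc3c2CCO3)n2cnnc12` has not yet been measured. It differs from compound 1 in one place: methyl(pyridin-3-yl)amino in place of phenylcarbamoyl on an aromatic carbon. The phenylcarbamoyl group of compound 1 is gone, and with it the one hydrogen-bond donor; the methyl(pyridin-3-yl)amino group brings two hydrogen-bond acceptors and no donor.

Among the measured compounds shown here, no measured pair in this set shows a comparable change, so there is nothing to calibrate the step against. On that basis a modest rise toward faster clearance is expected, a step from compound 1 to compound 4 of a 1.4-fold higher number from compound 1 to compound 4 (0.15 log units; within the scatter), though one that may well fall within the scatter. Compound 4 is therefore estimated at 20 mL.min-1.g-1, with a range from 8 mL.min-1.g-1 to 50 mL.min-1.g-1.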

Compound 4, intrinsic clearance in microsomes: 80 mL.min-1.g-1
The estimate for compound 4 lay 4.0-fold (0.60 log units) below the measured number; the measured number lies above the stated range.
By their numbers in this assay, from the lowest: compounds 1, 2 and 3 (each within the scatter of the next); then compound 4.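

In this assay, among the compounds shown here, putting methyl(pyridin-3-yl)amino in place of phenylcarbamoyl on this aromatic carbon gives a 5.7-fold higher number from compound 1 to compound 4 (0.76 log units; beyond the scatter), the only step in the set and one that lies beyond the scatter. The earlier compounds shown here could not be told apart on this read-out and included no pair differing in one place, so they gave no sign that a change at this carbon could move clearance by more than the scatter. Here, a single exchange on the shared core separates two compounds clearly, with the number rising toward fast clearance, but nothing available gives a reason for that rise.

The exchange alters several things at once: the linking carbonyl and the amide hydrogen leave, a methyl arrives on the linking nitrogen, and the phenyl ring gives way to a pyridine ring, so the step cannot be assigned to any one of them. Groups such as pyridin-3-ylcarbamoyl or methyl(phenyl)amino on the same carbon would separate these parts, and whether either stays nearer compound 1 or nearer compound 4 remains open.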